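Working notes: three inactive analogues and a fourth candidate

This account rests on a few compounds, and the source may have more. Where it says the series, first, only, none or still open, it means among the compounds named here.

Compound 1 `CCCc1nc(C)c2c(C)nn(CC)c(=O)n12` was tested in a functional assay for inhibition, with Homo sapiens as the target; a lower number here means a stronger inhibitor, a higher number a weaker inhibitor. In this assay compound 1 reaches only a limit, > 48000 nM. Compound 2 `CCCc1nc(C)c2c(C)nn(CCC)c(=O)n12` likewise gives only a limit, > 48000 nM. Compound 3 `CSc1nncc2c(C)nc(C(C)C)n12` also gives only a limit, > 48000 nM. The change hydrogen in place of methyl on a saturated chain carbon, two bonds along the chain from an aromatic nitrogen gives a step that the two limits leave unreadable from compound 2 to compound 1. How the core of compound 3 differs from that of compound 2 is not broken down here. Compound 4 `CCc1nc(C)c2cnnc(SC)n12` carries hydrogen in place of methyl on a saturated chain carbon bound to an aromatic carbon and a saturated chain carbon, the same kind of change as in compound 1, though the place differs: a saturated chain carbon bound to an aromatic carbon and a saturated chain carbon, rather than one two bonds along the chain from an aromatic nitrogen. Given (the limit of > 48000 nM in this assay, at which 3 of the 3 values shown sit), the step from compound 3 to compound 4 is expected to be a step that the limit leaves unreadable from compound 3 to compound 4, and compound 4 is estimated at 60000 nM in this assay, most likely again as a limit.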

Compound 4, half-maximal inhibitory concentration: > 48000 nM
Compound 4 gave a limit, no number; the forecaster's own chance of this, stated with the estimate: 85%; the middle value is on the limit's open side.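

For the compounds shown here, compound 3 and compound 4 both stand only as limits, so no step between them can be read. The compounds shown leave open which structural change, if any, would give a measurable inhibition, since all values sit at a single limit: the limit of > 48000 nM in this assay, at which 4 of the 4 values shown sit.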